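This account rests on a few compounds, and the source may have more. Where it says the series, first, only, none or still open, it means among the compounds named here.

Measured so far, with the compounds assessed in a functional assay on B16-F10 cells (Mus musculus) for antiproliferative activity, read by ELISA and MTT assay, with a stated time of 48 h; a lower number here means a stronger inhibitor, a higher number a weaker inhibitor:

compound 1, `O=C(/C=C/c1ccccc1)NS(=O)(=O)c1ccc(Cl)cc1`, for which compound 1 gives 2.2 ug/mL
compound 2, `O=C(/C=C/c1ccc(Br)cc1)NS(=O)(=O)c1ccc(Cl)cc1`, for which compound 2 gives 5.2 ug/mL
compound 3, `O=C(/C=C/c1ccc([N+](=O)[O-])cc1)NS(=O)(=O)c1ccc(F)cc1`, for which compound 3 gives 2.2 ug/mL

Compound 3 stands level with compound 1 at the digits reported, and together these two hold the lowest numbers of the three. Compound 2 sits apart from both: a 2.4-fold higher number from compound 1 to compound 2 (0.37 log units; beyond the scatter), a modest move that lies beyond the scatter, and compound 2 also shows a higher number than compound 3.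

The next compound is compound 4, `O=C(/C=C/c1ccc([N+](=O)[O-])cc1)NS(=O)(=O)c1ccc(Cl)cc1`. Compound 4 differs from compound 3 in one place: chloro in place of fluoro on an aromatic carbon. For the measured compounds named here, none of the measured steps touches this position or this exchange; the only measured step, that from compound 1 to compound 2, swaps a halogen for a hydrogen on the other aromatic ring, and even that was modest. Going by the values given here, with no direct precedent, the expected result in this assay for compound 4 is a number close to that of compound 3, with a step of a 1.1-fold higher number from compound 3 to compound 4 (0.06 log units; within the scatter) judged within the scatter. Compound 4 is therefore estimated at 2.5 ug/mL, with a likely range from 1.2 ug/mL to 5.5 ug/mL.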

Compound 4, half-maximal inhibitory concentration: 13.7 ug/mL
Beside the measured number, compound 4's estimate is 5.5-fold (0.74 log units) below it; measured number above the stated range.
By their numbers in this assay, from the lowest: compounds 1 and 3 (each within the scatter of the next); then compound 2; then compound 4.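

Within this assay, the exchange of 4-fluorophenyl for 4-chlorophenyl is not a silent swap between two halogens: with the nitro group kept in place, it gives a 6.2-fold higher number from compound 3 to compound 4 (0.79 log units; beyond the scatter). Among the compounds carrying the 4-chlorophenyl group, the nitro group also gives the highest number, with a 6.2-fold higher number from compound 1 to compound 4 (0.79 log units; beyond the scatter) against the hydrogen and a 2.6-fold higher number from compound 2 to compound 4 (0.42 log units; beyond the scatter) against the bromo group, which leaves compound 4 the weakest of the four. No measurement shown here explains any of these steps.

The compounds shown leave open whether the exchange of 4-fluorophenyl for 4-chlorophenyl would give a step of this size with a hydrogen or a bromo group on the other ring, or whether it is tied to the nitro group. They also leave open how a methoxy group, an amine or a carboxylic acid would read in place of the nitro group, and how a 4-bromophenyl or an unsubstituted phenyl would read in place of the 4-chlorophenyl.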